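A few compounds are considered here, and "the series" means these few. Any claim that something is new, unique, unknown or untested is made for them only; others in the source may bear on it.

Among the compounds with values here, in a functional assay on HCT-116 cells (Homo sapiens) for cytotoxicity (on this read-out lower numbers stand for stronger inhibition and higher numbers for weaker inhibition), compound 1 `C[C@@H]1O[C@@H](n2c3ccccc3c3c4c(c5c6ccccc6ccc5c32)C(=O)NC4=O)[C@H](O)[C@H](O)[C@H]1O` gives 3100 nM, and compound 2 `O=C1NC(=O)c2c1c1c3ccccc3ccc1c1c2c2ccccc2n1[C@H]1OC[C@@H](O)[C@@H](O)[C@H]1O` gives 6000 nM, so compound 2 stands level with the only other number available. Compound 3 `O=C1NC(=O)c2c1c1c3ccccc3ccc1c1c2c2ccccc2n1[C@@H]1O[C@H](CO)[C@@H](O)[C@H](O)[C@H]1O` differs from compound 2 by a group of 11 heavy atoms (6 carbon, 5 oxygen; one six-membered non-aromatic ring with 1 hetero atom) in place of a group of 9 heavy atoms (5 carbon, 4 oxygen; one six-membered non-aromatic ring with 1 hetero atom), on an aromatic nitrogen, and the group that enters is 3,4,5-trihydroxy-6-(hydroxymethyl)oxan-2-yl. Within the data shown here, the one measured step bearing on this is a 1.9-fold higher number from compound 1 to compound 2 (0.29 log units; within the scatter), likewise a change of the group on an aromatic nitrogen, so no step beyond the scatter is expected in this assay. The estimate amounts to an expected 1.3-fold lower number from compound 2 to compound 3 (0.12 log units; within the scatter). For compound 3 the expected value is 4500 nM, with an estimated range of 1500 nM to 13000 nM.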

Compound 3, half-maximal inhibitory concentration: 5100 nM
Compound 3: middle estimate off by 1.1-fold (0.05 log units), on the low side; measured number inside the range.
By their numbers in this assay, from the lowest: compounds 1, 3 and 2 (each within the scatter of the next).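

In this assay the step of a 1.2-fold lower number from compound 2 to compound 3 (0.07 log units; within the scatter) stays within the scatter, and so does a 1.6-fold higher number from compound 1 to compound 3 (0.22 log units; within the scatter), where 3,4,5-trihydroxy-6-(hydroxymethyl)oxan-2-yl takes the place of 3,4,5-trihydroxy-6-methyloxan-2-yl on the aromatic nitrogen. The three groups at this place therefore cannot be told apart on this read-out, and that now includes a direct exchange of methyl for hydroxymethyl. No evidence is available to account for this result. The compounds shown leave open whether a group of another kind on this nitrogen, such as an amine-bearing ring or a plain alkyl chain, would give a step beyond the scatter.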